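The source may report more compounds than this note shows. Statements on the series, on what has been measured and on what is new or still open speak of the compounds shown alone.

Measured compounds:
- compound 1 `CC(C)(C)OC(=O)N1CCc2c(sc(NC(=O)Nc3ccc(Cl)cc3)c2C(N)=O)C1` gives > 25000 nM as a limit of the assay
- compound 2 `CC(C)(C)C[N+]1(C)CCc2c(sc(NC(=O)Nc3ccc(Cl)cc3)c2C(N)=O)C1` gives 290 nM as a number
- compound 3 `CC(C)C[N+]1(C)CCc2c(sc(NC(=O)Nc3ccc(Cl)cc3)c2C(N)=O)C1` gives 380 nM as a number

Compound 1 gives no number in a functional assay (strain AB) with Danio rerio as the target, read by microscopy, with a stated time of 1 h (on this read-out lower numbers stand for an effect already at smaller amounts and higher numbers for an effect only at larger amounts of compound), only a limit (the limit of > 25000 nM in this assay, at which 1 of the 3 values shown sits). The change to compound 4 `CC(C)CN1CCc2c(sc(NC(=O)Nc3ccc(Cl)cc3)c2C(N)=O)C1` puts isobutyl in place of tert-butoxycarbonyl on an amine nitrogen in a ring. Among the measured compounds shown here, the only measured step (a 1.3-fold higher number from compound 2 to compound 3 (0.12 log units; within the scatter)) lies within the scatter and does not touch this swap, so it gives no size to carry over. Isobutyl also stands in compound 3 (380 nM), and on that value alone a move to lower numbers in this assay is expected, of uncertain size. The expected step is large (an at least 16-fold lower number from compound 1 to compound 4 (1.22 log units; beyond the scatter)), and a result that again gives only a limit cannot be ruled out. Estimated for compound 4: 1500 nM as the middle, 250 nM as the lower end and 15000 nM as the upper end of the expected range.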

Compound 4, half-maximal effective concentration: 4510 nM
The estimate for compound 4 lay 3.0-fold (0.48 log units) below the measured number; measured number inside the range.
By their numbers in this assay, from the lowest: compounds 2 and 3 (each within the scatter of the next); then compound 4. At a limit, above all of these: compound 1.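

In this assay, isobutyl in place of tert-butoxycarbonyl on an amine nitrogen in a ring brings the series from no number to a measurable one (an at least 5.5-fold lower number from compound 1 to compound 4 (0.74 log units; beyond the scatter)). Isobutyl alone does not account for the values of the charged compounds: compound 4 gives 4510 nM and compound 3 gives 380 nM in this assay with a further methyl on the same nitrogen. Compound 1 remains a limit, so the step has a minimum size only: the limit of > 25000 nM in this assay, at which 1 of the 4 values shown sits.

Open, on these data alone, is how acetyl, benzyl or a longer chain on this nitrogen would read, with or without the further methyl. Also open, as far as these compounds go, is whether the swap from tert-butoxycarbonyl to isobutyl reads the same on any core other than the shared one.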